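Swapping the Aryl Group on the Amine Nitrogen

The source may hold more compounds than are shown below. What is called first, only, known or untested is meant among the compounds shown, and "the series" means these compounds.

In a functional assay on ECa-109 cells for inhibition, with ECa-109 cell line (Homo sapiens) as the target, read by sulforhodamine B assay (on this read-out lower numbers stand for stronger inhibition and higher numbers for weaker inhibition), compound 1 `COc1cccc(NC2=CC(=O)c3nc4n(c3C2=O)[C@H]2OC[C@@H](O)[C@H]2OC4)c1` gives 7620 nM. Compound 3 `CCOc1ccc(NC2=CC(=O)c3nc4n(c3C2=O)[C@H]2OC[C@@H](O)[C@H]2OC4)cc1` gives 3210 nM in this assay, a change described as a 2.4-fold lower number from compound 1 to compound 3 (0.38 log units; beyond the scatter). Compound 2 `COc1ccccc1NC1=CC(=O)c2c(nc3n2[C@H]2OC[C@@H](O)[C@H]2OC3)C1=O` gives only a limit of this assay, > 4000 nM. That limit is the limit of > 4000 nM in this assay, at which 1 of the 3 values shown sits, so where compound 2 truly stands is not known. Compound 4 `O=C1C(Nc2ccc(I)cc2)=CC(=O)c2c1nc1n2[C@H]2OC[C@@H](O)[C@H]2OC1` has not yet been measured; it differs from compound 2 by 4-iodophenyl in place of 2-methoxyphenyl on an amine nitrogen. For the measured compounds named here, the only measured step that changes the group on this amine nitrogen, from compound 1 to compound 3, is modest, and compound 2 offers only a floor, so no large movement is expected. The estimate for compound 4 is 5000 nM, with a range of 1500 nM to 20000 nM. This is expected to read as a step that the limit leaves unreadable from compound 2 to compound 4.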

Compound 4, half-maximal inhibitory concentration: 2530 nM
The estimate for compound 4 lay 2.0-fold (0.30 log units) above the measured number; the measured number falls inside the stated range.
By their numbers in this assay, from the lowest: compounds 4 and 3 (each within the scatter of the next); then compound 1.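

Replacing 2-methoxyphenyl with 4-iodophenyl on this amine nitrogen gives an at least 1.5-fold lower number from compound 2 to compound 4 (0.19 log units; that floor lies within the scatter), so the true size of the change cannot be read. Compound 2 is known only as a limit: the limit of > 4000 nM in this assay, at which 1 of the 4 values shown sits. Compound 3 at 3210 nM and compound 4 at 2530 nM lie within the scatter of each other, so among the compounds shown, an iodine on the aryl ring reads at the same level as an ethoxy group. As far as these compounds go, whether 4-chlorophenyl or 4-fluorophenyl would read like 4-iodophenyl stays open, as does the effect of a plain alkyl chain in place of the aryl group.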